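The compounds below may be only part of what the source reports. "The series", "measured", "known", "first", "only" and "open" are said of these compounds alone.

Measured compounds:
- Compound 1, `COC(=O)/C=C/c1cccc(N(Cc2ccc(/C=C/c3cccc(C(F)(F)F)c3)cc2)C(=O)C(C)C)c1`: 267 nM
- Compound 2, `COC(=O)/C=C/c1cccc(N(Cc2ccc(/C=C/c3cccc(C(F)(F)F)c3)cc2)C(=O)NC(C)C)c1`: 932 nM
- Compound 3, `COC(=O)/C=C/c1cccc(N(Cc2ccc(/C=C/c3ccccc3F)cc2)C(=O)C2CCCCC2)c1`: 64 nM

All three values come from an assay on isolated protein with Bile acid receptor (Homo sapiens) as the target; on this read-out higher numbers stand for an effect only at larger amounts of compound and lower numbers for an effect already at smaller amounts. Among them compound 1 stands second highest: compound 2 sits nearer, and compound 3 furthest away with its lower number. Among the compounds with values here, the one step that can be read off directly, a 3.5-fold higher number from compound 1 to compound 2 (0.54 log units; beyond the scatter), concerns the carbonyl side of the shared core and is modest.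

Compound 4, `COC(=O)/C=C/c1cccc(N(Cc2ccc(/C=C/c3cccc(F)c3)cc2)C(=O)C(C)C)c1`, is not yet measured. It differs from compound 1 in one place: fluoro in place of trifluoromethyl on an aromatic carbon. Within the data shown here, none of the measured steps touches this position, so no direct guide exists. Compound 3 also carries a fluoro on that terminal ring, but it differs from compound 1 in two places, so its lower value cannot be attributed to the ring change alone. The expectation for compound 4 is therefore a small step, if any, in this assay, not clearly beyond the scatter: a 1.3-fold higher number from compound 1 to compound 4 (0.12 log units; within the scatter). Compound 4 is estimated at 350 nM, within 120 nM to 1100 nM.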

Compound 4, half-maximal effective concentration: 71 nM
Beside the measured number, compound 4's estimate is 4.9-fold (0.69 log units) above it; measured number outside the range, below it.
By their numbers in this assay, from the lowest: compounds 3 and 4 (each within the scatter of the next); then compound 1; then compound 2.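

Within the data shown here, until now, no pair of measured compounds in this assay isolated a change on this aromatic ring, so compound 3 could not show whether the ring substituent matters on its own. With everything else held constant, fluoro in place of trifluoromethyl gives a 3.8-fold lower number from compound 1 to compound 4 (0.58 log units; beyond the scatter), so this position, meta to a large group, does affect the read-out, and the change with one heavy atom in place of four gives the lower number. No measurement at hand gives a reason for this shift.

On these data alone, two groups at one position cannot show a trend, so it remains open how a plain hydrogen, a chlorine or a methoxy group would compare there. As far as these compounds go, it is also open whether the same swap would give a similar step with isopropylamino on the carbonyl.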